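The source may report more compounds than this note shows. Statements on the series, on what has been measured and on what is new or still open speak of the compounds shown alone.

Series notes. Two compounds of this set have a number in a physicochemical assay for lipophilicity, read by HPLC, at pH 7.4; a higher number here means a more lipophilic compound, a lower number a more polar compound. Compound 1 `C[C@@H](Oc1cc2onc(CCC(=O)O)c2cc1Cl)c1ccc(F)cn1` gives 2.47 in this assay. Compound 2 `CC(C)Cc1cc2oc(=O)n(CCC(=O)O)c2cc1Cl` gives 3.03 in this assay and so stands at the top of the two values measured, with compound 1 the only other point, lower by a margin beyond the usual scatter. Compounds 1 and 2 differ in several places at once, so nothing more is read from their pair than what the two values show.

Compound 3 `O=C(O)CCn1c(=O)oc2cc(OCC3CC3)c(Cl)cc21` is not yet measured in this assay. It keeps the core of compound 2 and differs from it in one place: cyclopropylmethoxy in place of isobutyl on an aromatic carbon. Among the measured compounds shown here, no pair of measured compounds shows an exchange of this kind, so the expected size of the step rests on the change alone and on the value of compound 2. The step expected in this assay is a number 0.43 log units lower from compound 2 to compound 3 (beyond the scatter), a modest fall, of a size at the edge of the scatter. For compound 3 the estimated distribution coefficient in this assay is 2.6, with a range from 2.2 to 3.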

Compound 3, distribution coefficient: 2.09
For compound 3 the middle estimate is 0.51 log units above the measured one; the whole stated range lies above it.
By their numbers in this assay, from the lowest: compound 3; then compound 1; then compound 2.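

Among the compounds shown here, with the core of compound 2 held fixed, this position gives the first single exchange of the series that can be read in this assay: cyclopropylmethoxy in place of isobutyl on an aromatic carbon, ortho to a chloro group, amounts to a number 0.94 log units lower from compound 2 to compound 3 (beyond the scatter) and so shows that the number responds to the group at this place. Both groups hold 4 carbon atoms, while the entering group adds an oxygen, a hydrogen-bond acceptor and a three-membered ring, so this one pair carries several changes together and cannot separate them. No measured information at hand accounts for the size of the step.

Going by these compounds, it remains open how much of the step goes with the oxygen and how much with the ring: isobutoxy and cyclopropylethyl at this position on the same core would pull the two apart. On these data alone, it is also open whether the exchange gives a step of similar size with a fluoro group in place of the chloro group, or on the core of compound 1.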